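The source may report more compounds than this note shows. Statements on the series, on what has been measured and on what is new or still open speak of the compounds shown alone.

Measured compounds in a toxicity assay on THP-1 cells (Homo sapiens) for inhibition; a lower number here means that less compound is tolerated, a higher number that more compound is tolerated:

Compound 1, `COc1ccc(-c2cnc(NC(=O)c3cccc([N+](=O)[O-])c3)n2C)cc1`, gives > 100000 nM, which is a limit of the assay and not a number.
Compound 2, `COc1ccc(-c2cnc(NC(=O)c3cccc(C#N)c3)n2C)cc1`, gives > 100000 nM, again a limit of the assay.
Compound 3, `Cc1ccc(C(=O)Nc2ncc(-c3ccccc3)o2)cc1`, gives 26000 nM.

Compound 2 therefore stands at the limit of this assay; its value is not a number. Going by the values given here, the single step that touches it, a step that the two limits leave unreadable from compound 1 to compound 2, joins two limits and its size cannot be read. Among the compounds with values here, compound 3 is the only compound of the three with a numerical value, and no step connects it to compound 2.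

Compound 4, `COc1ccc(-c2cnc(NC(=O)c3cnc[nH]3)n2C)cc1`, differs from compound 2 in one place: 1H-imidazol-5-yl in place of 3-cyanophenyl on a carbonyl carbon. Within the data shown here, no measured step covers an exchange of this kind on a carbonyl carbon. Among the measured compounds shown here, the one measured step, a step that the two limits leave unreadable from compound 1 to compound 2, gives no size. What the data do show is the limit of > 100000 nM in this assay, at which 2 of the 3 values shown sit, and compound 2 shares that limit. The expectation for compound 4 is that it also lies at or beyond the limit, with no step beyond the scatter. Compound 4 is therefore estimated at 120000 nM, ranging from 50000 nM to 300000 nM. The step this estimate implies, a step that the limit leaves unreadable from compound 2 to compound 4, is expected to be none beyond the scatter.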

Compound 4, half-maximal cytotoxic concentration: > 100000 nM
Compound 4 ended at the assay's limit; the forecaster's own chance of this, stated with the estimate: 70%; the middle value is on the limit's open side.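

Compound 2 and compound 4 both stand at a limit of this assay and not at a number, so no step can be read between them. The compounds shown leave open how much of compound 2 or compound 4 is actually tolerated, since what they show is only this: the limit of > 100000 nM in this assay, at which 3 of the 4 values shown sit.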